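The source may report more compounds than this note shows. Statements on the series, on what has been measured and on what is new or still open speak of the compounds shown alone.

Compound 2, `COc1cc(C)cc(-c2nn(CC#N)cc2-c2ccnc(-c3ccc(N(C)C)cc3)c2)c1`, sits within a small group of three measured compounds that share one core and carry a nitrile-bearing chain on it. In a functional assay on SK-MEL-5 cells (Homo sapiens) for cytotoxicity, read by sulforhodamine B assay, with a stated time of 48 h, tested at 100 nM (on this read-out lower numbers stand for a stronger effect and higher numbers for a weaker effect at the one concentration tested), compound 2 gives -22%. Compound 1, `COc1cc(C)cc(-c2c(-c3ccnc(-c4ccc(N(C)C)cc4)c3)cnn2CC#N)c1`, differs from it in how the two aryl groups are arranged around the core, and in this assay compound 1 gives -21%, a number that lies within the usual scatter of the value for compound 2, so the two cannot be told apart. Compound 3, `COc1cc(C)cc(-c2nn(CC#N)cc2-c2ccc(-c3cccc(C(C)=O)c3)nc2)c1`, carries an acetyl-bearing phenyl on its pyridine instead of the dimethylamino-bearing one, and in this assay compound 3 gives 65%, far beyond the scatter from compound 2 and showing a much weaker effect.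

Compound 4, `Cc1cc(O)cc(-c2nn(CC#N)cc2-c2ccnc(-c3ccc(N(C)C)cc3)c2)c1`, has not yet been measured. It differs from compound 2 in one place: hydrogen in place of methyl on an oxygen on an aromatic ring. For the measured compounds named here, no pair of measured compounds shows what this kind of change does here, so there is no step to lean on. A step of modest size in this assay is expected, if anything toward weaker effect, and it may well stay within the scatter. Compound 4 is therefore expected to give about 5% in this assay, somewhere between -25% and 60%. That expectation corresponds to a step of a number 27 percentage points higher from compound 2 to compound 4 (beyond the scatter).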

Compound 4, a percentage reported as activity, at one concentration (the size of the read-out at that concentration, not a potency): 82%
Beside the measured number, compound 4's estimate is 77 percentage points below it, outside the stated range (above it).
By their numbers in this assay, from the lowest: compounds 2 and 1 (each within the scatter of the next); then compound 3; then compound 4.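

All three earlier compounds carry the methoxy group, so they could not show whether this oxygen substituent matters. Replacing methoxy with hydroxy, which removes only the methyl on an oxygen on an aromatic ring, gives a number 104 percentage points higher from compound 2 to compound 4 (beyond the scatter) in this assay and shows that this position is highly sensitive to this small change, with the strong effect of compound 2 lost at the one concentration tested. No measurement shown here explains why such a small change has so large an effect.

The compounds shown leave open whether the effect depends on the methyl group itself or on the free hydroxy, and an ethoxy group or an amine at this place would help separate those two readings. They also leave open whether the same change would have a step of similar size on the other arrangement of the two aryl groups around the shared core, as in compound 1, or alongside the acetyl-bearing phenyl of compound 3.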